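Methoxy for methyl: carrying one step onto compound 3

The source may hold more compounds than are shown below. What is called first, only, known or untested is meant among the compounds shown, and "the series" means these compounds.

Compound 1 `Cc1ccc(-c2cc(/N=C3/NC(=O)CS3)cs2)cc1` and compound 2 `COc1ccc(-c2cc(/N=C3/NC(=O)CS3)cs2)cc1` share one core; compound 3 `Cc1ccc(/C=C2\S/C(=N\c3nc(-c4ccc(Cl)cc4)cs3)NC2=O)cc1` and the unmeasured compound 4 `COc1ccc(/C=C2\S/C(=N\c3nc(-c4ccc(Cl)cc4)cs3)NC2=O)cc1` share another, and the difference between the two cores is not broken down here. In a functional assay on SW-620 cells (Homo sapiens) for cytotoxicity, read by MTT assay, with a stated time of 72 h (on this read-out higher numbers stand for weaker inhibition and lower numbers for stronger inhibition), compound 1 gives > 50000 nM, a limit of the assay rather than a number. Compound 2 likewise gives > 50000 nM, again a limit. The change methoxy in place of methyl on an aromatic carbon therefore makes a step that the two limits leave unreadable from compound 1 to compound 2, since the limit of > 50000 nM in this assay, at which 2 of the 3 values shown sit, holds both values. Among the compounds with values here, compound 3 gives 890 nM, the only number in the set. The change methoxy in place of methyl on an aromatic carbon is the same change at the same place, so the earlier pair lends it no readable size. Compound 4 is expected to give 900 nM, between 400 nM and 2500 nM. The step this estimate means, a 1.0-fold higher number from compound 3 to compound 4 (0.00 log units; within the scatter), is expected to stay within scatter. It rests on compound 3 at 890 nM and on the earlier step being unreadable.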

Compound 4, half-maximal inhibitory concentration: 50 nM
Compound 4: the middle estimate sits 18-fold (1.26 log units) above what was measured; measured number outside the range, below it.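

In this assay, methoxy in place of methyl on an aromatic carbon gives an 18-fold lower number from compound 3 to compound 4 (1.25 log units; beyond the scatter), a large step on the core of compound 3. The same change on the core of compound 1 cannot be read, because both values of that pair are limits: the limit of > 50000 nM in this assay, at which 2 of the 4 values shown sit. Within the data shown here, the series therefore neither confirms nor refutes carrying the change from one core to the other, and the one readable pair gives a size on one core only.

Open, as far as these compounds go, is whether an amine or a carboxylic acid on the same aromatic carbon would follow methoxy or methyl on the core of compound 3. Also open, from the compounds shown here alone, is whether a longer chain, such as ethoxy, would keep the step.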